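The source may hold more compounds than are shown below. What is called first, only, known or untested is meant among the compounds shown, and "the series" means these compounds.

Measured so far:
compound 1, `CCCCCCCCCCCCNC(=O)[C@@H](NC(=O)c1cc2ccccc2n1C)[C@@H](C)O`: > 200000 nM
compound 2, `CCCCCCCCCCCCCCNC(=O)[C@@H](NC(=O)c1cc2ccccc2[nH]1)[C@@H](C)O`: 10500 nM

Going by the values given here, in a functional assay on HepG2 cells (Homo sapiens) for cytotoxicity, read by MTT assay, with a stated time of 48 h (on this read-out lower numbers stand for stronger inhibition and higher numbers for weaker inhibition), compound 2 gives 10500 nM, the only numeric value in this set. Compound 1 returns only a limit, > 200000 nM, not a number. Compound 3, `CCCCCCCCCCCCCCNC(=O)[C@@H](NC(=O)c1cc2ccccc2n1C)[C@@H](C)O`, differs from compound 2 by methyl in place of hydrogen on an aromatic nitrogen. Compound 1 already carries that methyl, on a shorter chain, and sits at the limit of > 200000 nM in this assay, at which 1 of the 2 values shown sits; this points toward a weakening step rather than none. Compound 3 is therefore expected to come out weaker, with an estimated step of a 5.7-fold higher number from compound 2 to compound 3 (0.76 log units; beyond the scatter). The estimate for compound 3 is 60000 nM, with a real chance that only a limit is reported.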

Compound 3, half-maximal inhibitory concentration: 34500 nM
Beside the measured number, compound 3's estimate is 1.7-fold (0.24 log units) above it; low and high end bracket the measured number.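

In this assay, methyl in place of hydrogen on an aromatic nitrogen gives a 3.3-fold higher number from compound 2 to compound 3 (0.52 log units; beyond the scatter), so on this chain the methylated compound still returns a number. With that methyl held, ethyl in place of hydrogen on a saturated chain carbon gives an at least 5.7-fold lower number from compound 1 to compound 3 (0.76 log units; beyond the scatter), so chain length also moves the read-out. That step rests on a limit, not a number, for compound 1: the limit of > 200000 nM in this assay, at which 1 of the 3 values shown sits.

Going by these compounds, the effect of a longer chain, or of ethyl or a carboxylic acid side chain on the aromatic nitrogen, remains open. Also open, on these data alone, is whether the methyl step keeps its size on the shorter chain of compound 1.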